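Amide variation on a shared core: cytotoxicity notes

The compounds below may be only part of what the source reports. "The series", "measured", "known", "first", "only" and "open" are said of these compounds alone.

compound 1 `Cc1c(C)c2c(c(C)c1OC(=O)CCC(=O)O)CCC(C)(C(=O)NC1CC(C)(C)N([O])C(C)(C)C1)O2` — > 300000 nM
compound 2 `Cc1c(C)c2c(c(C)c1OC(=O)CCC(=O)O)CCC(C)(C(=O)NCC1CC(C)(C)N([O])C1(C)C)O2` — > 300000 nM

In a toxicity assay on cells (Cricetulus griseus) for cytotoxicity, read by MTT assay, with a stated time of 72 h (a lower number here means a stronger inhibitor, a higher number a weaker inhibitor), compound 1 gives > 300000 nM, which is a limit of the assay and not a number. Compound 2 likewise gives > 300000 nM, also a limit. The step that the two limits leave unreadable from compound 1 to compound 2 is therefore unreadable; (the limit of > 300000 nM in this assay, at which 2 of the 2 values shown sit). Compound 3 `Cc1c(C)c2c(c(C)c1OC(=O)CCC(=O)NC1CC(C)(C)N([O])C(C)(C)C1)CCC(C)(C(=O)NC1CC(C)(C)N([O])C(C)(C)C1)O2` differs from compound 1 by a group of 12 heavy atoms (9 carbon, 2 nitrogen, 1 oxygen; one six-membered non-aromatic ring with 1 hetero atom) in place of one oxygen atom, on a carbonyl carbon. Among the compounds with values here, no measured step bears on this change, and compound 1 stands only at a limit, so no direction can be read from the series. Compound 3 is expected to give 300000 nM, between 100000 nM and 1000000 nM, an expected step of a number no higher from compound 1 to compound 3 (the limit leaves the size open).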

Compound 3, half-maximal inhibitory concentration: 54000 nM
Beside the measured number, compound 3's estimate is 5.6-fold (0.74 log units) above it; the whole stated range lies above it.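

In this assay, this position gives a readable change where the earlier change on an amide-type nitrogen did not: putting the group of 12 heavy atoms in place of the hydroxy on a carbonyl carbon gives an at least 5.5-fold lower number from compound 1 to compound 3 (0.74 log units; beyond the scatter). The value for compound 1 is a limit, so the full size of the step stays open: the limit of > 300000 nM in this assay, at which 2 of the 3 values shown sit.

As far as these compounds go, whether a simple amine or a methyl ester on this carbonyl carbon would move the number the same way stays open. So does whether the ring itself matters here, rather than any replacement of the hydroxy.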